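Urea aryl swap: dichlorophenyl to trifluoromethylphenyl

A few compounds are considered here, and "the series" means these few. Any claim that something is new, unique, unknown or untested is made for them only; others in the source may bear on it.

Among the compounds with values here, compound 3 `COc1cc(Cl)cc(-c2nn(-c3cccc(NC(=O)Nc4ccc(Cl)c(Cl)c4)c3)cc2-c2ccncc2)c1` gives 1480 nM in a functional assay on A549 cells (Homo sapiens) for inhibition, read by sulforhodamine B assay, with a stated time of 48 h (on this read-out higher numbers stand for weaker inhibition and lower numbers for stronger inhibition), the highest of the three numbers so far. Compound 1 `COc1cc(Cl)cc(-c2nn(-c3cccc(NC(=O)Nc4ccc(Cl)c(C(F)(F)F)c4)c3)cc2-c2ccncc2)c1` gives 680 nM, and compound 2 `COc1cc(Cl)cc(-c2nn(-c3cccc(NC(=O)Nc4cc(C(F)(F)F)cc(C(F)(F)F)c4)c3)cc2-c2ccncc2)c1` gives 370 nM, the lowest of the set. Within the data shown here, the one step that changes a single place, a 2.2-fold higher number from compound 1 to compound 3 (0.34 log units; beyond the scatter), runs counter to the direction now being taken.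

Compound 4 `COc1cc(Cl)cc(-c2nn(-c3cccc(NC(=O)Nc4cccc(C(F)(F)F)c4)c3)cc2-c2ccncc2)c1` differs from compound 3 in the urea aryl: 3-(trifluoromethyl)phenyl in place of 3,4-dichlorophenyl on an amide-type nitrogen. Among the measured compounds shown here, the step from compound 1 to compound 3 bears on this directly, as it exchanged trifluoromethyl for chloro and gave a modestly higher number; compound 4 puts a trifluoromethyl back, but compound 1 still carries a chloro that compound 4 lacks, and no measured pair isolates that removal. The expectation is therefore a modest lowering of the number, a 1.9-fold lower number from compound 3 to compound 4 (0.27 log units; within the scatter), with added uncertainty from the missing chloro. Compound 4 is estimated at 800 nM, with a range from 350 nM to 1800 nM.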

Compound 4, half-maximal inhibitory concentration: 730 nM
Compound 4: the middle estimate sits 1.1-fold (0.04 log units) above what was measured, within the range that was stated.
By their numbers in this assay, from the lowest: compounds 2, 1 and 4 (each within the scatter of the next); then compound 3.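

In this assay, 3-(trifluoromethyl)phenyl in place of 3,4-dichlorophenyl on the amide-type nitrogen gives a 2.0-fold lower number from compound 3 to compound 4 (0.31 log units; beyond the scatter), so a single trifluoromethyl with no chloro is enough to separate this aryl from the dichlorinated one. Hydrogen in place of chloro gives a 1.1-fold higher number from compound 1 to compound 4 (0.03 log units; within the scatter), and hydrogen in place of trifluoromethyl gives a 2.0-fold higher number from compound 2 to compound 4 (0.30 log units; within the scatter); both steps lie within the scatter, so neither the chloro of compound 1 nor the second trifluoromethyl of compound 2 shows a clear contribution on this aryl. No supporting data bear on the reason for these differences.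

Still open, from the compounds shown here alone, is how the urea aryl responds to a group of another kind, such as an amine or a carboxylic acid. Going by these compounds, the unsubstituted phenyl, which would show what the single trifluoromethyl itself contributes, is also open.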